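Removing the para-methyl from an anilide: cytotoxicity in HeLa cells

The source may hold more compounds than are shown below. What is called first, only, known or untested is meant among the compounds shown, and "the series" means these compounds.

Compound 1 `C=CC1=C(C(=O)NCCC)C(c2ccc(F)cc2)OC1`: in a functional assay on HeLa cells (Homo sapiens) for cytotoxicity, read by MTT assay, with a stated time of 24 h (on this read-out lower numbers stand for stronger inhibition and higher numbers for weaker inhibition), compound 1 gives > 100000 nM, a limit of the assay.
Compound 2 `C=CC1=C(C(=O)Nc2ccccc2OC)C(c2ccc(F)cc2)OC1`: in this assay compound 2 gives > 100000 nM, a limit of the assay.
Compound 3 `C=CC1=C(C(=O)Nc2ccc(C)cc2)C(c2ccc(F)cc2)OC1`: in this assay compound 3 gives > 100000 nM, a limit of the assay.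

All three measured compounds share one core and differ only in the group on the amide-type nitrogen. None of them gives a number in this assay (the limit of > 100000 nM in this assay, at which 3 of the 3 values shown sit). The steps between them are therefore unreadable: a step that the two limits leave unreadable from compound 1 to compound 2, a step that the two limits leave unreadable from compound 1 to compound 3 and a step that the two limits leave unreadable from compound 2 to compound 3 say nothing about size or direction. Compound 3 thus stands at the same limit as the other two, with no ranking possible among them.

Compound 4 `C=CC1=C(C(=O)Nc2ccccc2)C(c2ccc(F)cc2)OC1` differs from compound 3 in one place: hydrogen in place of methyl on an aromatic carbon of a six-membered aromatic ring of carbon only, para to a large group. Among the compounds with values here, no measured step bears on this change, since every step between the measured compounds is unreadable. With the two aryl amides compound 2 and compound 3 both at the limit, the loss of a single carbon is expected to leave compound 4 at or near that limit, so the step that the limit leaves unreadable from compound 3 to compound 4 is expected to be none beyond the scatter. Compound 4 is estimated at 150000 nM, within 50000 nM to 500000 nM.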

Compound 4, half-maximal inhibitory concentration: > 100000 nM
Compound 4 ended at the assay's limit; the forecaster's own chance of this, stated with the estimate: 85%; the middle value does not contradict the limit.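

In this assay compound 4 gives > 100000 nM, a limit of the assay. The steps linking compound 4 with compound 1, compound 2 and compound 3 cannot be read, since all four sit at the same limit: the limit of > 100000 nM in this assay, at which 4 of the 4 values shown sit. The compounds shown leave open how strongly any of them acts on these cells, and whether any group on the amide-type nitrogen separates one from another.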